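Replacing a Small Amine with an Ethylpiperazine Ring

A few compounds are considered here, and "the series" means these few. Any claim that something is new, unique, unknown or untested is made for them only; others in the source may bear on it.

Four compounds share one core and differ only in the group attached to the amine. Compound 1 `COc1cc(Oc2cccc(Nc3ccccc3)c2)cc(OC)c1CNCc1ccccc1` gives 3340 nM in a functional assay on HT-29 cells (Homo sapiens) for inhibition, read by MTT assay, with a stated time of 72 h; on this read-out lower numbers stand for stronger inhibition and higher numbers for weaker inhibition. Compound 2 `CNCc1c(OC)cc(Oc2cccc(Nc3ccccc3)c2)cc1OC` gives 7430 nM, the highest of the three measured numbers, while compound 3 `COc1ccc([C@@H](C)NCc2c(OC)cc(Oc3cccc(Nc4ccccc4)c3)c(OC)c2OC)cc1` gives 1630 nM, the lowest. Among the compounds with values here, the single one-point step measured is a 2.2-fold higher number from compound 1 to compound 2 (0.35 log units; beyond the scatter), so replacing phenyl with hydrogen on a saturated chain carbon bound to an amine nitrogen raised the number modestly. Compound 4 `CCN1CCN(Cc2c(OC)cc(Oc3cccc(Nc4ccccc4)c3)cc2OC)CC1` has not been measured; it differs from compound 2 by 4-ethylpiperazin-1-yl in place of methylamino on a saturated chain carbon bound to an aromatic carbon. Within the data shown here, no measured step involves a ring at the amine, so the step from compound 1 to compound 2 is the only guide, and compound 4 runs the other way, adding atoms where compound 2 lost them. Compounds 1 and 3, both larger than compound 2 at the amine, show lower numbers. A lowering is therefore expected, a 1.7-fold lower number from compound 2 to compound 4 (0.22 log units; within the scatter), of uncertain size. Compound 4 is estimated at 4500 nM, with a range from 1500 nM to 13000 nM.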

Compound 4, half-maximal inhibitory concentration: > 20000 nM
Compound 4 gave a limit, no number; the forecaster's own chance of this, stated with the estimate: 5%; at least 4.4-fold (0.64 log units) between middle value and limit.
By their numbers in this assay, from the lowest: compound 3; then compound 1; then compound 2. At a limit, above all of these: compound 4.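

Compound 4 has only a limit in this assay, not a number: the limit of > 20000 nM in this assay, at which 1 of the 4 values shown sits. Placing 4-ethylpiperazin-1-yl on the saturated chain carbon gives an at least 2.6-fold higher number from compound 2 to compound 4 (0.43 log units; beyond the scatter), and measured against benzylamino the same group gives an at least 5.9-fold higher number from compound 1 to compound 4 (0.77 log units; beyond the scatter). The earlier step showed only that benzylamino gave a lower number than methylamino, whereas this result shows that a larger group at this place does not by itself lower the number.

The entering group differs from methylamino in several ways at once, as it brings a ring and an ethyl group and has no hydrogen-bond donor, so the compounds shown cannot tell these changes apart. A dimethylamino group, a morpholine ring or an unsubstituted piperazin-1-yl ring at this place would help to separate them.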